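The source may report more compounds than this note shows. Statements on the series, on what has been measured and on what is new or still open speak of the compounds shown alone.

Three compounds built on one shared core have numbers in a functional assay on HeLa cells (Homo sapiens) for antiproliferative activity, read by MTT assay, with a stated time of 72 h; a lower number here means a stronger inhibitor, a higher number a weaker inhibitor. Compound 1 (`COc1cccc(N2C(=O)COc3ccc(-c4cccc(NS(=O)(=O)c5ccc(F)cc5)c4)cc32)c1`) carries 3-methoxyphenyl on an amide-type nitrogen in a ring, and its > 40000 nM is a limit of the assay, not a number. Compound 2 (`CC(C)N1C(=O)COc2ccc(-c3cccc(NS(=O)(=O)c4ccc(F)cc4)c3)cc21`) carries isopropyl there and gives 22700 nM. Compound 3 (`O=C1COc2ccc(-c3cccc(NS(=O)(=O)c4ccc(F)cc4)c3)cc2N1c1ccc(Cl)cc1`) carries 4-chlorophenyl and gives 35000 nM. Its nearest neighbour on the scale shows a 1.5-fold higher number from compound 2 to compound 3 (0.19 log units; within the scatter), so these two numbers cannot be told apart.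

Compound 4 (`O=C1COc2ccc(-c3cccc(NS(=O)(=O)c4ccc(F)cc4)c3)cc2N1c1ccccc1`) has not yet been measured. The change is hydrogen in place of chloro on an aromatic carbon, or 4-chlorophenyl to phenyl. Going by the values given here, no measured step makes exactly this change. The closest evidence comes from swapping the whole group on that nitrogen, which gave an at least 1.1-fold lower number from compound 1 to compound 3 (0.05 log units; that floor lies within the scatter) and an at least 1.7-fold lower number from compound 1 to compound 2 (0.24 log units; that floor lies within the scatter), together with the step between compound 2 and compound 3 already given. None of these is shown to go beyond the scatter, and the new change is a smaller edit than any of them. No shift beyond the scatter is therefore expected, and the expected step is a 1.2-fold lower number from compound 3 to compound 4 (0.07 log units; within the scatter). The assay may also report only a limit, as it did for compound 1. For compound 4 the estimated value is 30000 nM, with an expected range from 15000 nM to 60000 nM.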

Compound 4, half-maximal inhibitory concentration: 17700 nM
Compound 4: middle estimate off by 1.7-fold (0.23 log units), on the high side, within the range that was stated.
By their numbers in this assay, from the lowest: compounds 4, 2 and 3 (each within the scatter of the next). At a limit, above all of these: compound 1.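

Taking the chloro off the 4-chlorophenyl group in this assay gives a 2.0-fold lower number from compound 3 to compound 4 (0.30 log units; within the scatter), and swapping the whole group on the amide-type nitrogen for phenyl in place of isopropyl gives a 1.3-fold lower number from compound 2 to compound 4 (0.11 log units; within the scatter), so neither change can be told from ordinary assay variation. Going by these compounds alone, the first step beyond the scatter comes from a change on the same aromatic ring, hydrogen in place of methoxy, which gives an at least 2.2-fold lower number from compound 1 to compound 4 (0.35 log units; beyond the scatter), whereas the chloro step does not clear the scatter. Compound 1 stands at a limit and not at a number, so that step gives only a minimum size: the limit of > 40000 nM in this assay, at which 1 of the 4 values shown sits.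

Still open, on these data alone, is whether an amine or a carboxylic acid on this aromatic carbon, in place of hydrogen or chloro, would move the number beyond the scatter. It is also unclear whether a longer chain on the amide-type nitrogen, in place of isopropyl or phenyl, would separate from compound 2 and compound 4 in this assay.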